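This account rests on a few compounds, and the source may have more. Where it says the series, first, only, none or still open, it means among the compounds named here.

Measured in a functional assay on A549 cells (Homo sapiens) for inhibition, read by sulforhodamine B assay, with a stated time of 48 h; a higher number here means a weaker inhibitor, a lower number a stronger inhibitor:
Compound 1 `COc1ccc(C(c2ccc(OC(C)CN(C)C)cc2)c2cccc3ccccc23)c(OC)c1OC`: 11400 nM
Compound 2 `COc1ccc(C(c2ccc(OCCO)cc2)c2cccc3ccccc23)c(OC)c1OC`: > 20000 nM (a limit)

Compound 2 has no exact number on this scale. Its entry, > 20000 nM, is a limit of the assay. Compound 3 `COc1ccc(C(c2ccc(O)cc2)c2cccc3ccccc23)c(OC)c1OC` has hydrogen in place of 2-hydroxyethyl on an oxygen on an aromatic ring, so that 4-(2-hydroxyethoxy)phenyl becomes 4-hydroxyphenyl. Going by the values given here, only one measured step involves a change on this oxygen, and it is bounded from one side only: an at least 1.7-fold higher number from compound 1 to compound 2 (0.24 log units; that floor lies within the scatter). On the strength of that step alone, compound 3 is expected to show no clear move beyond the scatter in this assay, and no firm direction can be expected. The estimated step is an at least 1.3-fold lower number from compound 2 to compound 3 (0.12 log units; that floor lies within the scatter). A limit may well be reported again. The estimate for compound 3 is 15000 nM. The expected range for compound 3 runs from 6000 nM to 30000 nM.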

Compound 3, half-maximal inhibitory concentration: 16400 nM
Compound 3: the middle estimate sits 1.1-fold (0.04 log units) below what was measured; the range from low to high includes it.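

In this assay, putting hydrogen on this oxygen gives a 1.4-fold higher number from compound 1 to compound 3 (0.16 log units; within the scatter), so the whole 1-((dimethylamino)methyl)ethyl group can go without a change that can be told from the scatter. The other new comparison, 2-hydroxyethyl to hydrogen, gives an at least 1.2-fold lower number from compound 2 to compound 3 (0.08 log units; that floor lies within the scatter), and with only a floor inside the scatter it does not separate these two groups. Compound 2 still has no exact number, only a limit of the assay: the limit of > 20000 nM in this assay, at which 1 of the 3 values shown sits.

The compounds shown leave open whether any group on this oxygen can move the number clearly beyond the scatter in this assay. From the compounds shown here alone, a methyl, a carboxylic acid on a short chain or a longer chain ending in a dimethylamino group could each test this, and the direction of any such move remains unknown.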